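The compounds below may be only part of what the source reports. "The series", "measured", "known", "first", "only" and "open" are said of these compounds alone.

Measured so far in a functional assay on SMMC-7721 cells (Homo sapiens) for inhibition, read by CCK-8 assay, with a stated time of 72 h, tested at 8 uM; on this read-out higher numbers stand for more inhibition of growth at the one concentration tested and lower numbers for less inhibition of growth:

compound 1 `Nc1ccccc1NC(=O)/C=C/c1ccc(CSc2ccc(Cl)cc2)cc1`: 16.5%
compound 2 `Nc1ccccc1NC(=O)c1ccc(CSc2cccc(F)c2)cc1`: 83%
compound 3 `Nc1ccccc1NC(=O)c1ccc(CSc2ccc(C(F)(F)F)cn2)cc1`: 7.57%

Of these three, compound 2 stands highest at 83%. The gaps between it and both of the others are beyond the usual scatter of this kind of measurement. So it makes a good starting point for asking what a single change can do.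

The next compound is compound 4 `Nc1ccccc1NC(=O)c1ccc(CSc2ccc(Cl)cc2)cc1`, which keeps the rest of compound 2 and alters one group: 4-chlorophenyl in place of 3-fluorophenyl on a sulfur. In words, a 4-chlorophenyl takes the place of a 3-fluorophenyl on a sulfur.

Going by the values given here, no measured pair shows this change on its own, so any forecast rests on indirect evidence. Compound 1 carries the same 4-chlorophenyl on a sulfur and gives only 16.5%, but it also differs from compound 4 elsewhere, which makes it a weak guide. Compound 3, with yet another group on the sulfur, gives 7.57%, so the high number of compound 2 does not carry over to every group in that place.

A fall beyond the scatter is therefore expected, estimated as a number 33 percentage points lower from compound 2 to compound 4 (beyond the scatter). For compound 4 the estimated value is 50%, with an expected range from 15% to 85%.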

Compound 4, percent growth inhibition at one concentration: 16.5%
Estimate against measurement, compound 4: 33.5 percentage points above; the range from low to high includes it.
By their numbers in this assay, from the lowest: compounds 3, 1 and 4 (each within the scatter of the next); then compound 2.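

In this assay, putting 4-chlorophenyl in place of 3-fluorophenyl on a sulfur gives a number 66.5 percentage points lower from compound 2 to compound 4 (beyond the scatter). Going by these compounds alone, this is the first direct view of this position: with the rest of the molecule held constant, this one change separates the high value of compound 2 from a much lower one, so growth inhibition at this concentration depends strongly on the group carried by the sulfur. No measurement shown explains the fall.

The swap changes two things at once, the halogen and its place on the ring, so the compounds shown leave open which of the two matters, and a 3-chlorophenyl or a 4-fluorophenyl on the same sulfur would help to separate them. On these data alone, it also remains open whether a plain phenyl, a 3-methoxyphenyl or a 3-aminophenyl in this place would keep the value of compound 2 at 83% or lose it as compound 4 does.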